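A few compounds are considered here, and "the series" means these few. Any claim that something is new, unique, unknown or untested is made for them only; others in the source may bear on it.

Compound 1 `Cn1cncc1CN1CC(N(CCn2cccc2)S(=O)(=O)c2ccccn2)Cc2cc(C#N)ccc21` gives 12.4 10^-6 cm/s in an ADME assay on Caco-2 cells (Homo sapiens) for permeability, in the apical to basolateral direction; on this read-out higher numbers stand for higher permeability and lower numbers for lower permeability. Compound 2 `Cn1cncc1CN1CC(N(CC2CCN(C(=O)C(C)(C)C)CC2)S(=O)(=O)c2ccccn2)Cc2cc(C#N)ccc21`, which carries 1-((tert-butyl)carbonyl)piperidin-4-yl in place of (1H-pyrrol-1-yl)methyl on a saturated chain carbon bound to a sulfonamide nitrogen, gives 0.5 10^-6 cm/s in this assay, and the change is a 25-fold lower number from compound 1 to compound 2 (1.39 log units; beyond the scatter). Compound 3 `Cn1cnc(S(=O)(=O)N(CCn2cccc2)C2Cc3cc(C#N)ccc3N(Cc3cncn3C)C2)c1` gives 0.3 10^-6 cm/s in this assay, and here the change is a 41-fold lower number from compound 1 to compound 3 (1.62 log units; beyond the scatter). Compound 2 therefore sits far beneath compound 1, while its number and that of compound 3 lie within the usual scatter of each other, so no order between those two can be read.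

Compound 4 `Cn1cncc1CN1CC(N(CC2CCN(S(=O)(=O)c3ccccc3)CC2)S(=O)(=O)c2ccccn2)Cc2cc(C#N)ccc21` is the new member, and the change from compound 2 is phenylsulfonyl in place of (tert-butyl)carbonyl on an amine nitrogen in a ring. Within the data shown here, none of the measured steps alters the group on that amine nitrogen: the step from compound 1 to compound 2 does touch the same chain, but it swaps the whole chain rather than the cap on the piperidine, and the step from compound 1 to compound 3 concerns a different place altogether. With nothing measured in the same spot, the change is expected to move the number little, and a step of a 1.2-fold higher number from compound 2 to compound 4 (0.08 log units; within the scatter) is expected, within the scatter. Compound 4 is accordingly estimated at 0.6 10^-6 cm/s in this assay, with a range from 0.2 10^-6 cm/s to 2 10^-6 cm/s.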

Compound 4, apparent permeability: 0.1 10^-6 cm/s
For compound 4 the middle estimate is 6.0-fold (0.78 log units) above the measured one; measured number below the stated range.
By their numbers in this assay, from the lowest: compound 4; then compounds 3 and 2 (each within the scatter of the next); then compound 1.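

The group on this amine nitrogen in a ring is not a silent place: with the rest of the molecule unchanged, phenylsulfonyl in place of (tert-butyl)carbonyl gives a 5.0-fold lower number from compound 2 to compound 4 (0.70 log units; beyond the scatter) in this assay. The earlier steps shown here replaced the whole chain or altered the group on a sulfonyl sulfur, so they could not show that a change confined to this nitrogen, three ring bonds from the ring atom that bears a large group, can by itself shift the number beyond the scatter. The two groups differ in several ways at once, since phenylsulfonyl brings a six-membered aromatic ring of carbon only and a sulfur in place of the carbonyl carbon, and nothing available here explains the step.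

The compounds shown do not separate the part played by the sulfonyl link from that of the phenyl ring, which a methylsulfonyl or a benzoyl group on the same nitrogen would help to do. They also leave open how a very different cap, such as a small alkyl group or a carboxylic acid, would behave at this place.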